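The source may report more compounds than this note shows. Statements on the series, on what has been measured and on what is new or still open speak of the compounds shown alone.

Measured compounds in a functional assay on COLO 320 cells (Homo sapiens) for antiproliferative activity, read by WST assay, with a stated time of 72 h; a lower number here means a stronger inhibitor, a higher number a weaker inhibitor:
- compound 1 `Cc1noc(-c2cc3cc(Cl)ccc3[nH]2)n1` gives 19500 nM
- compound 2 `COc1ccc2[nH]c(-c3nc(-c4ccc(Cl)cc4)no3)cc2c1` gives 12800 nM
- compound 3 `Fc1ccc2[nH]c(-c3nc(-c4ccc(Cl)cc4)no3)cc2c1` gives > 50000 nM; this is a limit of the assay, not a number

Compound 3 thus stands at the weak end of the three; its value is only the assay limit, a point at which one of the three values sits (the limit of > 50000 nM in this assay, at which 1 of the 3 values shown sits). The step from compound 2 to compound 3 was an at least 3.9-fold higher number from compound 2 to compound 3 (0.59 log units; beyond the scatter), though with the limit its true size is open.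

Compound 4 `Clc1ccc(-c2noc(-c3cc4cc(Cl)ccc4[nH]3)n2)cc1` differs from compound 3 by chloro in place of fluoro on an aromatic carbon. Among the compounds with values here, no measured step covers a fluoro-to-chloro exchange directly; the only step on this carbon, an at least 3.9-fold higher number from compound 2 to compound 3 (0.59 log units; beyond the scatter), points to a weaker number when methoxy is lost, and compound 1, which also carries chloro at that place on the shared core but a methyl in place of the chlorophenyl, gives 19500 nM. A small change is therefore expected, about an at least 1.6-fold lower number from compound 3 to compound 4 (0.22 log units; that floor lies within the scatter) in this assay. Compound 4 is estimated at 30000 nM, in the range 10000 nM to 60000 nM, with a fair chance that only a limit is reported.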

Compound 4, half-maximal inhibitory concentration: 25000 nM
For compound 4 the middle estimate is 1.2-fold (0.08 log units) above the measured one; measured number inside the range.
By their numbers in this assay, from the lowest: compounds 2, 1 and 4 (each within the scatter of the next). At a limit, above all of these: compound 3.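

In this assay, going by these compounds, the fluoro-to-chloro exchange at this position gives (an at least 2.0-fold lower number from compound 3 to compound 4 (0.30 log units; that floor lies within the scatter)), but compound 3 stands only at a limit, so the true size of this step stays open: (the limit of > 50000 nM in this assay, at which 1 of the 4 values shown sits). Chloro in place of methoxy gives (a 2.0-fold higher number from compound 2 to compound 4 (0.29 log units; within the scatter)), so compound 4 is not separated from compound 2, whereas fluoro in place of methoxy gave (an at least 3.9-fold higher number from compound 2 to compound 3 (0.59 log units; beyond the scatter)); loss of methoxy therefore does not by itself carry a change beyond the scatter. With chloro on the shared core, 4-chlorophenyl in place of methyl gives (a 1.3-fold higher number from compound 1 to compound 4 (0.11 log units; within the scatter)), so these two groups are not told apart here.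

On these data alone, whether an amine or a carboxylic acid at this position would shift the number beyond the scatter remains open. Also open, as far as these compounds go, is how a longer chain in place of the 4-chlorophenyl would read.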